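Tetrahydroisoquinoline-tetrahydroquinoline series: chain-terminus variation

The source may report more compounds than this note shows. Statements on the series, on what has been measured and on what is new or still open speak of the compounds shown alone.

Measured compounds:
compound 1 `c1ccc2c(c1)CN[C@@H](CN(CCCCNCC1CCOCC1)[C@H]1CCCc3cccnc31)C2` – 52.9 nM
compound 2 `c1ccc2c(c1)CN[C@@H](CN(CCCCNC1CCOCC1)[C@H]1CCCc3cccnc31)C2` – 29.4 nM
compound 3 `CC1(C)CCC(NCCCCN(C[C@H]2Cc3ccccc3CN2)[C@H]2CCCc3cccnc32)CC1` – 77.6 nM

Read-out throughout is a functional assay on cells for antagonist activity at C-X-C chemokine receptor type 4 (Homo sapiens), read by fluorescence and calcium flux, with stated times of 25 min and 90 s; a higher number here means a weaker inhibitor, a lower number a stronger inhibitor. Compound 3 gives the highest number of the three; its nearest neighbour is compound 1 a 1.5-fold higher number from compound 1 to compound 3 (0.17 log units; within the scatter), its furthest is compound 2 a 2.6-fold higher number from compound 2 to compound 3 (0.42 log units; beyond the scatter). All three steps among the measured compounds exchange only the group on the secondary amine nitrogen at the chain terminus: a 1.8-fold lower number from compound 1 to compound 2 (0.26 log units; within the scatter) and a 1.5-fold higher number from compound 1 to compound 3 (0.17 log units; within the scatter) stay within the scatter, and only a 2.6-fold higher number from compound 2 to compound 3 (0.42 log units; beyond the scatter) is modest.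

Compound 4 `CC(C)(N)CCCN(C[C@H]1Cc2ccccc2CN1)[C@H]1CCCc2cccnc21` differs from compound 3 more deeply: a group of 4 heavy atoms (3 carbon, 1 nitrogen; no ring) in place of a group of 10 heavy atoms (9 carbon, 1 nitrogen; one six-membered non-aromatic ring of carbon only), on a saturated chain carbon, three bonds along the chain from an amine nitrogen. For the measured compounds named here, the chain terminus thereby loses its ring and its secondary amine, and a primary amine on a branched carbon takes their place; no measured step covers a change of this kind, so the measured steps set only a loose frame. Given that compound 3 already stands at the top of the three numbers 77.6 nM, a further rise is expected for compound 4, estimated at 160 nM with a range of 50 nM to 500 nM, a step of a 2.1-fold higher number from compound 3 to compound 4 (0.31 log units; beyond the scatter).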

Compound 4, half-maximal inhibitory concentration: 24.6 nM
The estimate for compound 4 lay 6.5-fold (0.81 log units) above the measured number; the whole stated range lies above it.
By their numbers in this assay, from the lowest: compounds 4, 2, 1 and 3 (each within the scatter of the next, the first and the last beyond it).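

At this chain terminus, the 1-amino-1-methylethyl group, which has no ring, gives a 3.2-fold lower number from compound 3 to compound 4 (0.50 log units; beyond the scatter) and a 2.2-fold lower number from compound 1 to compound 4 (0.33 log units; beyond the scatter) as modest steps, while a 1.2-fold lower number from compound 2 to compound 4 (0.08 log units; within the scatter) stays within the scatter. The earlier steps only exchanged groups on the secondary amine nitrogen and all kept a ring, whereas compound 4 shows that, among these compounds, ring and secondary amine can both leave without a higher number in this read-out. Nothing at hand explains this result.

Loss of the ring and arrival of the primary amine on a branched carbon come together in compound 4, so their separate contributions stay open. As far as these compounds go, a hydroxyl or a dimethylamino group on the same branched carbon would separate them, and how a longer chain would read is equally open.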